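Replacing the 4-isopropylpiperazin-1-yl group of compound 3

The source may report more compounds than this note shows. Statements on the series, on what has been measured and on what is new or still open speak of the compounds shown alone.

In an in vitro ADME assay on microsomes (Homo sapiens) for metabolic stability, read by LC-MS, with a stated time of 15 min (a lower number here means that the compound disappears faster, a higher number that the compound lasts longer), compound 1 `O=C(Nc1ccc(CO)cc1)Nc1ccc(-c2nc(N3C4CCC3COC4)nc(N3C4CCC3COC4)n2)cc1` gives < 0.0167 h, which is a limit. Compound 2 `CCN1CCN(c2ccc(NC(=O)Nc3ccc(-c4nc(C5CCOCC5)nc(N5C6CCC5COC6)n4)cc3)cc2)CC1` gives > 0.5 h, also a limit. Compound 3 `CC(C)N1CCN(c2ccc(NC(=O)Nc3ccc(-c4nc(C5CCOCC5)nc(N5C6CCC5COC6)n4)cc3)cc2)CC1` gives > 0.5 h, again a limit. Compound 3 therefore stands at the limit of > 0.5 h in this assay, at which 2 of the 3 values shown sit, with no number of its own.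

Compound 4 `CN(C)C1CCN(C(=O)c2ccc(NC(=O)Nc3ccc(-c4nc(C5CCOCC5)nc(N5C6CCC5COC6)n4)cc3)cc2)CC1` differs from compound 3 on an aromatic carbon of a six-membered aromatic ring of carbon only, para to a large group: (4-(dimethylamino)piperidin-1-yl)carbonyl in place of 4-isopropylpiperazin-1-yl on an aromatic carbon. In short, (4-(dimethylamino)piperidin-1-yl)carbonyl stands in place of 4-isopropylpiperazin-1-yl.

Among the measured compounds shown here, no measured step covers this replacement. For the measured compounds named here, the one measured step is a step that the two limits leave unreadable from compound 2 to compound 3, so it offers no size to carry forward. Going by the values given here, compound 1 stands at the limit of < 0.0167 h in this assay, at which 1 of the 3 values shown sits, but it differs from compound 3 in more than one place and offers no step.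

The expectation rests on compound 3, which gives > 0.5 h, a limit. Compound 4 is expected to stay close to it, with no definite direction and no step beyond the scatter. The expected step is a number no higher from compound 3 to compound 4 (the limit leaves the size open). For compound 4 the estimate is 0.5 h, with an expected range from 0.2 h to 1 h.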

Compound 4, half-life: > 0.5 h
Compound 4 gave a limit, no number; the forecaster's own chance of this, stated with the estimate: 60%; the middle value sits exactly at the limit.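

In this assay compound 4 gives > 0.5 h, which is a limit. Among the compounds shown here, compound 2, compound 3 and compound 4 all carry only limits, and no step among them can be read. The compounds shown leave open how far the half-lives of these three compounds lie past that limit, and whether (4-(dimethylamino)piperidin-1-yl)carbonyl and 4-isopropylpiperazin-1-yl differ at all in this assay.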